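The source may hold more compounds than are shown below. What is called first, only, known or untested is meant among the compounds shown, and "the series" means these compounds.

Within the data shown here, in a functional assay on HeLa cells (Homo sapiens) for antiproliferative activity, read by MTT assay, with a stated time of 72 h (on this read-out higher numbers stand for weaker inhibition and lower numbers for stronger inhibition), compound 1 `O=C1O[C@H]([C@@H](O)Cn2cc(-c3ccc(Br)cc3)nn2)C(OCc2ccccc2)=C1OCc1ccccc1` gives 3910 nM, the lowest of the three numbers measured so far. Compound 2 `O=C1O[C@H]([C@@H](O)Cn2cc(CNS(=O)(=O)c3ccc(F)cc3)nn2)C(OCc2ccccc2)=C1OCc1ccccc1` gives 25000 nM, and compound 3 `CCCCCCCCCCc1cn(C[C@H](O)[C@H]2OC(=O)C(OCc3ccccc3)=C2OCc2ccccc2)nn1` gives 22900 nM. Replacing the whole 4-bromophenyl weakened inhibition in both cases: a 6.4-fold higher number from compound 1 to compound 2 (0.81 log units; beyond the scatter) and a 5.9-fold higher number from compound 1 to compound 3 (0.77 log units; beyond the scatter), while a 1.1-fold lower number from compound 2 to compound 3 (0.04 log units; within the scatter). Among the measured compounds shown here, compound 4 `COc1ccc(-c2cn(C[C@H](O)[C@H]3OC(=O)C(OCc4ccccc4)=C3OCc3ccccc3)nn2)cc1` keeps that aromatic ring and alters only one group on it: methoxy in place of bromo on an aromatic carbon. For the measured compounds named here, no measured step exchanges one small group on this ring for another, so the two whole-ring swaps show only that this region matters. A change smaller than either of them is expected, and the step of a 1.3-fold higher number from compound 1 to compound 4 (0.11 log units; within the scatter) is expected to stay close to the scatter. Compound 4 is therefore estimated at 5000 nM, within 2000 nM to 15000 nM.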

Compound 4, half-maximal inhibitory concentration: 16400 nM
The estimate for compound 4 lay 3.3-fold (0.52 log units) below the measured number; the whole stated range lies below it.
By their numbers in this assay, from the lowest: compound 1; then compounds 4, 3 and 2 (each within the scatter of the next).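

In this assay, exchanging only the bromo for methoxy moves the number about as far as replacing the whole 4-bromophenyl did (a 4.2-fold higher number from compound 1 to compound 4 (0.62 log units; beyond the scatter)), so keeping the aromatic ring is not enough to hold the value of compound 1. Compound 4 cannot be separated from the two compounds lacking this ring (a 1.4-fold lower number from compound 3 to compound 4 (0.14 log units; within the scatter); a 1.5-fold lower number from compound 2 to compound 4 (0.18 log units; within the scatter)). Nothing available explains the gap between bromo and methoxy. Open, as far as these compounds go, is whether chloro, methyl or plain hydrogen at this place would stay near compound 1 or near compound 4.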